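The source may report more compounds than this note shows. Statements on the series, on what has been measured and on what is new or still open speak of the compounds shown alone.

Measured so far in a functional assay on UACC-62 cells (Homo sapiens) for inhibition, read by sulforhodamine B assay, with a stated time of 48 h; on this read-out lower numbers stand for stronger inhibition of growth and higher numbers for weaker inhibition of growth:
compound 1 `Cc1ccc(C2=NN(c3ccc(S(C)(=O)=O)cc3)C(=O)CC2)cc1` gives 460 nM
compound 2 `Cc1cc(O)ccc1C1=NN(c2ccc(S(C)(=O)=O)cc2)C(=O)CC1` gives 4000 nM

Compound 2 holds the higher of the two numbers, making it the weaker growth inhibitor of this pair. The change to compound 3 `CCc1ccc(C2=NN(c3ccc(S(C)(=O)=O)cc3)C(=O)CC2)cc1` is 4-ethylphenyl in place of 4-hydroxy-2-methylphenyl on a carbon with a double bond to nitrogen with 4-ethylphenyl in place of 4-hydroxy-2-methylphenyl on a carbon with a double bond to nitrogen. Among the compounds with values here, one measured step bears on this: an 8.7-fold higher number from compound 1 to compound 2 (0.94 log units; beyond the scatter) when 4-hydroxy-2-methylphenyl replaced 4-methylphenyl. That step lies beyond the scatter. Within the data shown here, compound 3 gives up the same group, so a step of similar size towards a lower number is expected in this assay although no measured step compares 4-ethylphenyl with 4-methylphenyl. The expected step is a 6.7-fold lower number from compound 2 to compound 3 (0.82 log units; beyond the scatter) as an estimate. For compound 3 the estimated value is 600 nM with an expected range from 200 nM to 1800 nM in this read-out.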

Compound 3, concentration for 50% growth inhibition: 780 nM
Beside the measured number, compound 3's estimate is 1.3-fold (0.11 log units) below it; measured number inside the range.
By their numbers in this assay, from the lowest: compounds 1 and 3 (each within the scatter of the next); then compound 2.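

Within this assay, the weak number of compound 2 proves specific to the 4-hydroxy-2-methylphenyl group rather than general to this place on the shared core: 4-ethylphenyl gives a 5.1-fold lower number from compound 2 to compound 3 (0.71 log units; beyond the scatter), with a hydrogen-bond donor and acceptor leaving and none entering. Extending the 4-methylphenyl group by one carbon gives a 1.7-fold higher number from compound 1 to compound 3 (0.23 log units; within the scatter), so compound 1 and compound 3 cannot be told apart here, and the 4-alkyl group accepts methyl in place of hydrogen on its chain carbon. No data on hand explain either step.

The compounds shown do not separate the hydroxy group from the added ring methyl in the loss seen with compound 2, as 4-hydroxyphenyl or 2-methyl-4-ethylphenyl groups would. From the compounds shown here alone, how far this place accepts a longer chain, such as 4-butylphenyl, or an amine also remains open.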